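The compounds below may be only part of what the source reports. "The series", "measured", "known", "first", "only" and "open" are said of these compounds alone.

Working notes on the series. In a functional assay on FM3A cells (Mus musculus) for inhibition, read by cell counting, with a stated time of 2 days (a higher number here means a weaker inhibitor, a lower number a stronger inhibitor), compound 1 `C=C(Br)C(=O)Nc1cccc(-c2cn3nc(Cc4ccccc4)sc3n2)c1` gives 3000 nM, the lowest of the three numbers in hand. Compound 3 `Nc1cccc(-c2cn3nc(Cc4ccccc4)sc3n2)c1` gives 4700 nM in this assay, and the step of a 1.6-fold higher number from compound 1 to compound 3 (0.19 log units; within the scatter) stays within the scatter. Compound 2 `Nc1cccc(-c2cn3nc(CCc4ccccc4)sc3n2)c1` gives 29000 nM in this assay; the step of a 6.2-fold lower number from compound 2 to compound 3 (0.79 log units; beyond the scatter) is the only one in the set beyond the scatter, and it concerns the group on the core.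

Compound 4 `C=C(Br)C(=O)Nc1cccc(-c2cn3nc(-c4cccs4)sc3n2)c1` is not yet measured in this assay. It differs from compound 1 by thiophen-2-yl in place of benzyl on an aromatic carbon. The step of a 6.2-fold lower number from compound 2 to compound 3 (0.79 log units; beyond the scatter) bears on this change, since it also varies the group at the same position of the core, and it was modest in size. The step of a 1.6-fold higher number from compound 1 to compound 3 (0.19 log units; within the scatter) touches a different place and offers no guidance. Among the measured compounds shown here, no measured compound carries thiophen-2-yl, so the direction is open. Compound 4 is therefore estimated to give about 4000 nM in this assay, within 1200 nM to 14000 nM. This estimate corresponds to an expected step of a 1.3-fold higher number from compound 1 to compound 4 (0.12 log units; within the scatter), within the scatter.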

Compound 4, half-maximal inhibitory concentration: 370 nM
Estimate against measurement, compound 4: 11-fold (1.03 log units) above, outside the stated range (below it).
By their numbers in this assay, from the lowest: compound 4; then compounds 1 and 3 (each within the scatter of the next); then compound 2.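

In this assay, thiophen-2-yl in place of benzyl gives an 8.1-fold lower number from compound 1 to compound 4 (0.91 log units; beyond the scatter), which shows that this aromatic carbon of the core tolerates a five-membered aromatic ring and that the number can fall well below those of the benzyl compounds. The earlier step at this position, a 6.2-fold lower number from compound 2 to compound 3 (0.79 log units; beyond the scatter), compared only two phenyl-bearing chains and did not test a different ring. Nothing measured here accounts for the size of the new step.

From the compounds shown here alone, it remains open whether the same change holds with a free amine in place of the (1-bromoethenyl)carbonyl group, as in compound 3. Also open, going by these compounds, is how a directly attached phenyl, furan-2-yl or pyridin-2-yl group at this position would compare with thiophen-2-yl.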